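Adding a methoxy group to a pyrazoline growth inhibitor

The source may hold more compounds than are shown below. What is called first, only, known or untested is meant among the compounds shown, and "the series" means these compounds.

Compound 1, `COc1ccc(C2CC(c3ccc(OCc4cn(Cc5ccc([N+](=O)[O-])cc5)nn4)cc3)=NN2C(C)=O)cc1`, was tested in a functional assay on THP-1 cells (Homo sapiens) for inhibition, read by sulforhodamine B assay, tested at 10 uM (a lower number here means less inhibition of growth, a higher number more inhibition of growth at the concentration tested), where compound 1 gives 15%. Two relatives, compound 2, `COc1cc(C2CC(c3ccccc3)=NN2C(C)=O)ccc1OCc1cn(Cc2ccc([N+](=O)[O-])cc2)nn1`, and compound 3, `COc1ccc(C2=NN(C(C)=O)C(c3ccc(OCc4cn(Cc5ccc([N+](=O)[O-])cc5)nn4)c(OC)c3)C2)cc1`, were run in the same test: compound 2 gives 0% and compound 3 gives 8%. Compound 2 and compound 3 differ only by methoxy in place of hydrogen on an aromatic carbon, and that change made a step of a number 8 percentage points higher from compound 2 to compound 3 (within the scatter). The difference between the core of compound 1 and the core of compound 2 is not broken down here.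

Compound 4, `COc1ccc(C2CC(c3ccc(OCc4cn(Cc5ccc([N+](=O)[O-])cc5)nn4)cc3)=NN2C(C)=O)cc1OC`, has not yet been measured. It differs from compound 1 by methoxy in place of hydrogen on an aromatic carbon. This is the same kind of change as that from compound 2 to compound 3, but its surroundings differ: in compound 4 the new group sits ortho to a methoxy group and meta to a large group, whereas in compound 3 it sits para to a large group. Because the earlier step was a number 8 percentage points higher from compound 2 to compound 3 (within the scatter), the expected step from compound 1 to compound 4 is a number 5 percentage points higher from compound 1 to compound 4 (within the scatter). Compound 4 is therefore estimated at 20%, most likely between 5% and 35%.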

Compound 4, percent growth inhibition at one concentration: 8%
For compound 4 the middle estimate is 12 percentage points above the measured one; the range from low to high includes it.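

In this assay, methoxy in place of hydrogen on an aromatic carbon of the core of compound 1 gave a step of a number 7 percentage points lower from compound 1 to compound 4 (within the scatter). Set beside the earlier step, this shows that the change did not carry over as a fixed amount from one core to the other: the same change on two cores in this assay, a number 8 percentage points higher (within the scatter) from compound 2 to compound 3 and a number 7 percentage points lower (within the scatter) from compound 1 to compound 4, 15 percentage points apart, beyond the scatter of two such steps. It does not show that methoxy itself raises growth inhibition on one core and lowers it on the other, since each step alone lies within the scatter, and two pairs cannot separate the effect of the core from that of where the new group sits, here ortho to a methoxy group and meta to a large group.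

The compounds shown leave open how a hydroxyl group, an amine or an ethoxy group would behave on this same aromatic carbon. They also leave open whether methoxy would give a third, different step on another core in this series.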